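Methyl on the Thiophene-Bound Phenyl in Glioblastoma Cell Growth Assay

The source may hold more compounds than are shown below. What is called first, only, known or untested is meant among the compounds shown, and "the series" means these compounds.

Compound 1 `Cc1ccc(C(=O)NNC(=S)Nc2csc(-c3ccccc3)c2)cc1` was tested in a functional assay on U-373MG ATCC cells (Homo sapiens) for inhibition, read by colorimetric assay and MTT assay, with a stated time of 72 h (a lower number here means a stronger inhibitor, a higher number a weaker inhibitor), where compound 1 gives 62000 nM. Compound 2 `Cc1ccc(C(=O)NNC(=S)Nc2csc(-c3ccc(C)cc3)c2)cc1` carries methyl in place of hydrogen on an aromatic carbon; in this assay compound 2 gives 38000 nM, so that a 1.6-fold lower number from compound 1 to compound 2 (0.21 log units; within the scatter). Compound 3 `COc1cc(OC)cc(C(=O)NNC(=S)Nc2csc(-c3ccccc3)c2)c1` has a different core; how the core of compound 1 and the core of compound 3 differ is not broken down here. In this assay compound 3 gives 40000 nM, which sits close to the values of compound 1 and compound 2.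

Compound 4 `COc1cc(OC)cc(C(=O)NNC(=S)Nc2csc(-c3ccc(C)cc3)c2)c1` has not yet been measured. Compound 4 is made from compound 3 by methyl in place of hydrogen on an aromatic carbon, the same change as that from compound 1 to compound 2. Going by the values given here, the step is expected to be a 1.4-fold lower number from compound 3 to compound 4 (0.15 log units; within the scatter), set beside a 1.6-fold lower number from compound 1 to compound 2 (0.21 log units; within the scatter), because a 1.6-fold lower number from compound 1 to compound 2 (0.21 log units; within the scatter) is the only measured instance of this change. Compound 4 is therefore estimated to give 28000 nM in this assay, with an expected range from 14000 nM to 56000 nM.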

Compound 4, half-maximal inhibitory concentration: 41000 nM
Estimate against measurement, compound 4: 1.5-fold (0.17 log units) below, within the range that was stated.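

In this assay, the change from phenyl to 4-methylphenyl gives a 1.0-fold higher number from compound 3 to compound 4 (0.01 log units; within the scatter). Set beside the earlier step, the change reads alike on the two cores: the same change on two cores in this assay, a 1.6-fold lower number (0.21 log units; within the scatter) from compound 1 to compound 2 and a 1.0-fold higher number (0.01 log units; within the scatter) from compound 3 to compound 4, 1.7-fold (0.22 log units) apart, within the scatter of two such steps Neither step lies beyond the scatter, so the pair shows no difference between the cores, but it does not show that the methyl alters the number on either core, and two cores cannot speak for the whole series.

The compounds shown leave open whether another group at the same place, such as an amine, a carboxylic acid or a longer chain, would give a step beyond the scatter. They also leave open whether such a step would carry from one core to the other.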